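Chloro to ethyl: from compound 2 to compound 3

This account rests on a few compounds, and the source may have more. Where it says the series, first, only, none or still open, it means among the compounds named here.

Three analogues of one shared core are on hand. Compound 1 `O=C1c2ccccc2C(=O)N1CNc1ccc(F)cc1` in an assay on isolated protein for inhibition of ribosomal protein S6 kinase alpha-2 (Homo sapiens), read by fluorescence, with a stated time of 20 min (a lower number here means a stronger inhibitor, a higher number a weaker inhibitor), gives 8740 nM, a weak reading. Compound 2 `O=C1c2ccccc2C(=O)N1CNc1ccc(Cl)cc1` in this assay gives "not determined" (no result reported), so no single number fixes where compound 2 stands, and the only anchor for the series is the weak value of compound 1. Compound 3 `CCc1ccc(NCN2C(=O)c3ccccc3C2=O)cc1` follows from compound 2 by one change: ethyl in place of chloro on an aromatic carbon, on an aromatic carbon of a six-membered aromatic ring of carbon only, para to a large group. Among the measured compounds shown here, no measured step is available from compound 2, so the size of the step cannot be read from the series; a swap of this kind is expected to stay within the scatter or shift potency only modestly in either direction. Compound 3 is therefore estimated at 10000 nM in this assay, with a range from 3000 nM to 35000 nM.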

Compound 3, half-maximal inhibitory concentration: 4310 nM
Estimate against measurement, compound 3: 2.3-fold (0.37 log units) above, and the stated range covers the measured number.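

At the aromatic carbon para to a large group, the series now has its first readable step: ethyl in place of fluoro gives, in this assay, a 2.0-fold lower number from compound 1 to compound 3 (0.31 log units; beyond the scatter) and so the position accepts ethyl without loss, although the gain is modest. The step from compound 2 to compound 3 cannot be read, since compound 2 has no result, and chloro therefore adds nothing to the comparison. Nothing at hand gives a reason for the step between fluoro and ethyl.

Going by these compounds, two substituents with readings are too few to show a trend at this position, and where chloro would fall relative to fluoro and ethyl stays open. Also open, on these data alone, is how a longer chain such as propyl, an amine or a carboxylic acid on this carbon would read, and whether any of them would move potency by more than a modest step.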